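Replacing the Aryl Amide of Compound 3 with a Benzyl Amide

The compounds below may be only part of what the source reports. "The series", "measured", "known", "first", "only" and "open" are said of these compounds alone.

Three compounds on one shared core have been tested in a functional assay on QGY7701 cells (Homo sapiens) for cytotoxicity, read by MTT assay, with a stated time of 24 h; a lower number here means a stronger inhibitor, a higher number a weaker inhibitor:
compound 1 `C=CC1=C(C(=O)NCc2ccccc2F)C(c2ccc(F)cc2)OC1` gives 51400 nM;
compound 2 `C=CC1=C(C(=O)NCC(C)C)C(c2ccc(F)cc2)OC1` gives > 100000 nM, which is a limit of the assay and not a number;
compound 3 `C=CC1=C(C(=O)Nc2cccc(C)c2)C(c2ccc(F)cc2)OC1` gives 56400 nM.

Compound 3 holds the higher of the two plain numbers, but the step of a 1.1-fold higher number from compound 1 to compound 3 (0.04 log units; within the scatter) lies within the scatter, so compound 1 and compound 3 cannot be told apart. Only compound 2 stands aside, at the limit of > 100000 nM in this assay, at which 1 of the 3 values shown sits, and the step of an at least 1.7-fold lower number from compound 2 to compound 3 (0.24 log units; that floor lies within the scatter) is a floor that also lies within the scatter.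

Compound 4 `C=CC1=C(C(=O)NCc2ccccc2)C(c2ccc(F)cc2)OC1` differs from compound 3 by benzyl in place of 3-methylphenyl on an amide-type nitrogen. Going by the values given here, two measured steps bear on this change. Among the compounds with values here, the step of a 1.1-fold higher number from compound 1 to compound 3 (0.04 log units; within the scatter) shows that exchanging a fluorinated benzyl for an aryl group on the amide nitrogen leaves the number essentially unchanged, while an at least 1.7-fold lower number from compound 2 to compound 3 (0.24 log units; that floor lies within the scatter) shows that a branched alkyl chain is the one group that drifts toward the limit. Benzyl sits close to the 2-fluorobenzyl of compound 1, so no step beyond the scatter is expected for a 1.0-fold lower number from compound 3 to compound 4 (0.01 log units; within the scatter). Compound 4 is therefore expected to give 55000 nM, with a range from 25000 nM to 120000 nM.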

Compound 4, half-maximal inhibitory concentration: 67600 nM
Compound 4: middle estimate off by 1.2-fold (0.09 log units), on the low side; the measured number falls inside the stated range.
By their numbers in this assay, from the lowest: compounds 1, 3 and 4 (each within the scatter of the next). At a limit, above all of these: compound 2.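

In this assay, benzyl and 3-methylphenyl on the amide-type nitrogen cannot be told apart, as a 1.2-fold higher number from compound 3 to compound 4 (0.08 log units; within the scatter) shows, and the same holds for hydrogen in place of fluoro on an aromatic carbon of the benzyl group, a 1.3-fold higher number from compound 1 to compound 4 (0.12 log units; within the scatter). Going by these compounds alone, the first of these steps swaps two groups with the same atoms, joined differently, and the second isolates the fluoro for the first time, yet neither step leaves the scatter. The step of an at least 1.4-fold lower number from compound 2 to compound 4 (0.17 log units; that floor lies within the scatter) is only a floor, so even the isobutyl group cannot yet be separated from benzyl. Compound 2 stands at a limit and not a number: the limit of > 100000 nM in this assay, at which 1 of the 4 values shown sits.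

On these data alone, whether an amine or a carboxylic acid on the benzyl ring would move the number stays open. So does the effect of any change elsewhere on the shared core, which is the same in all four compounds.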